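Replacing the sulfonyl group of compound 2 with an ether

The compounds below may be only part of what the source reports. "The series", "measured", "known", "first", "only" and "open" are said of these compounds alone.

Measured so far in a physicochemical assay for solubility, read by nephelometry, measured as kinetic solubility, with a stated time of 30 min; a lower number here means a less soluble compound, a higher number a more soluble compound:
- compound 1 `c1cc([C@H]2CC[C@]3(CC2)OOC2(O3)C3CC4CC(C3)CC2C4)ccc1OCCC1CCNCC1`: > 100 ug/mL (a limit of the assay)
- compound 2 `NC1CCN(S(=O)(=O)c2ccc([C@H]3CC[C@]4(CC3)OOC3(O4)C4CC5CC(C4)CC3C5)cc2)CC1`: 12.5 ug/mL

Within the data shown here, compound 2 gives 12.5 ug/mL, the only actual number in this assay so far. Compound 1 gives > 100 ug/mL, which is a limit and not a number.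

Compound 3 `c1cc([C@H]2CC[C@]3(CC2)OOC2(O3)C3CC4CC(C3)CC2C4)ccc1OCC1CCNCC1` carries (piperidin-4-yl)methoxy in place of (4-aminopiperidin-1-yl)sulfonyl on an aromatic carbon, para to a large group ((piperidin-4-yl)methoxy in place of (4-aminopiperidin-1-yl)sulfonyl on an aromatic carbon).

Among the measured compounds shown here, one measured step bears on this change: an at least 8.0-fold lower number from compound 1 to compound 2 (0.90 log units; beyond the scatter). That step brought in the same (4-aminopiperidin-1-yl)sulfonyl that now leaves, and it replaced 2-(piperidin-4-yl)ethoxy, whose name differs from the entering group only in the chain. The change to compound 3 is therefore read as roughly the reverse of that step, although a single step bounded by a limit fixes its size only loosely. A higher number is expected, beyond the scatter, with the estimated step being a 5.6-fold higher number from compound 2 to compound 3 (0.75 log units; beyond the scatter). For compound 3 the expected value is 70 ug/mL, with an estimated range of 25 ug/mL to 100 ug/mL.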

Compound 3, solubility: 12.5 ug/mL
Compound 3: the middle estimate sits 5.6-fold (0.75 log units) above what was measured, outside the stated range (below it).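

In this assay, (piperidin-4-yl)methoxy in place of (4-aminopiperidin-1-yl)sulfonyl on this aromatic carbon gives no change at the digits printed from compound 2 to compound 3 (within the scatter), so exchanging these two groups at this position leaves the read-out where it stood. The step of an at least 8.0-fold lower number from compound 1 to compound 2 (0.90 log units; beyond the scatter) can therefore no longer be tied to the (4-aminopiperidin-1-yl)sulfonyl group alone. The ether pair now carries a step of its own, an at least 8.0-fold lower number from compound 1 to compound 3 (0.90 log units; beyond the scatter), with (piperidin-4-yl)methoxy in compound 3 and 2-(piperidin-4-yl)ethoxy in compound 1 as the only difference.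

Compound 1 gives > 100 ug/mL, which is a limit and not a number, and the size of both steps from it stays open: the limit of > 100 ug/mL in this assay, at which 1 of the 3 values shown sits.

Whether the read-out follows the length of the ether chain rests on this single pair, and a 3-(piperidin-4-yl)propoxy chain, or a 2-aminoethoxy group with an open-chain amine in place of the piperidine, would bear on that question.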